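The source may hold more compounds than are shown below. What is called first, only, known or untested is meant among the compounds shown, and "the series" means these compounds.

Measured so far:
compound 1 `C#CCN(c1nc(-c2cccc(C)c2)no1)C1CCCCC1`, 25.9 ug/mL
compound 2 `C#CCOc1ccc(-c2noc(N(CC#C)C3CCCCC3)n2)cc1`, 101 ug/mL
compound 3 `C#CCN(c1nc(-c2ccc(C(F)(F)F)cc2)no1)C1CCCCC1`, 38.3 ug/mL

These three compounds share one core and differ only in the group on the outer aromatic ring. In an ADME assay on RAW264.7 cells (Mus musculus) for cytotoxicity, read by MTT assay, with a stated time of 48 h (a higher number here means that more compound is tolerated, a lower number that less compound is tolerated), compound 3 stands second highest of the three. Its nearest neighbour is compound 1, whose number is within the scatter of it, so no order between them can be read. The furthest is compound 2, and that gap is a 2.6-fold lower number from compound 2 to compound 3 (0.42 log units; beyond the scatter), beyond the scatter.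

Compound 4 is `C#CCN(c1nc(-c2ccccc2)no1)C1CCCCC1`. The change from compound 3 is hydrogen in place of trifluoromethyl on an aromatic carbon. For the measured compounds named here, only one measured step touches the same place on the ring, and it exchanges one group for another rather than removing a group altogether, so no measured step shows directly what losing the trifluoromethyl does. The comparable case of compound 1, which carries a small group, sits within the scatter of compound 3. The expected step is therefore a 1.2-fold lower number from compound 3 to compound 4 (0.06 log units; within the scatter), not beyond the scatter. Compound 4 is estimated at 33 ug/mL, within 15 ug/mL to 75 ug/mL.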

Compound 4, half-maximal cytotoxic concentration: 32.1 ug/mL
Compound 4: the middle estimate sits 1.0-fold (0.01 log units) above what was measured; the measured number falls inside the stated range.
By their numbers in this assay, from the lowest: compounds 1, 4 and 3 (each within the scatter of the next); then compound 2.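

Compound 4 carries only hydrogen on this aromatic carbon, which gives the outer ring a bare reference point in this assay. Against it, trifluoromethyl makes no readable difference (a 1.2-fold lower number from compound 3 to compound 4 (0.08 log units; within the scatter)), and neither does methyl (a 1.2-fold higher number from compound 1 to compound 4 (0.09 log units; within the scatter)), while propargyloxy alone stands apart (a 3.1-fold lower number from compound 2 to compound 4 (0.50 log units; beyond the scatter)). Among these four compounds, then, the higher number goes only with compound 2, and nothing measured here gives a reason for that gap.

As far as these compounds go, whether the number of compound 2 follows the oxygen link or the propargyl end remains open, and a methoxy group or a longer ether chain on this carbon would bear on that question. From the compounds shown here alone, how an amine or a carboxylic acid on the same carbon would compare also stays open.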